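This account rests on a few compounds, and the source may have more. Where it says the series, first, only, none or still open, it means among the compounds named here.

Measured compounds:
compound 1, `O=C(Nc1ccc(Cc2ccccc2)cc1)Nc1nn(C(=O)Nc2ccc(Cc3ccccc3)cc2)c2ccccc12` — > 100000 nM
compound 2, `Nc1nn(C(=O)Nc2ccc(Cc3ccccc3)cc2)c2ccccc12` — 6980 nM

Within the data shown here, in a functional assay on IGROV-1 cells (Homo sapiens) for inhibition, read by sulforhodamine B assay, with a stated time of 48 h (on this read-out lower numbers stand for stronger inhibition of growth and higher numbers for weaker inhibition of growth), compound 2 gives 6980 nM; this is the only number in hand. For compound 1 the value > 100000 nM is a limit of the assay, not a number (the limit of > 100000 nM in this assay, at which 1 of the 2 values shown sits). Compound 3, `CCCCOc1ccc(NC(=O)n2nc(N)c3ccccc32)cc1`, differs from compound 2 by butoxy in place of benzyl on an aromatic carbon. Among the measured compounds shown here, no measured step joins two compounds here, so the size of this change is unknown; a step within the scatter, in either direction, is expected. Compound 3 is estimated at 7000 nM, range 2000 nM to 30000 nM. The expected step is a 1.0-fold higher number from compound 2 to compound 3 (0.00 log units; within the scatter).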

Compound 3, concentration for 50% growth inhibition: 35500 nM
For compound 3 the middle estimate is 5.1-fold (0.71 log units) below the measured one, and the stated range ends below it.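

Butoxy in place of benzyl on an aromatic carbon, para to a large group, gives a 5.1-fold higher number from compound 2 to compound 3 (0.71 log units; beyond the scatter) in this assay. Among these compounds, this is the first measured step, and it shows that growth inhibition responds to the group at this position, with the benzyl of compound 2 giving the lower number. No measurement in hand bears on the cause of this step.

The swap changes ring, chain and oxygen at once, so compound 2 and compound 3 cannot separate these features. Going by these compounds, a phenoxy group or a butyl chain at this position would bear on that, and an amine remains open as well.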